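The compounds below may be only part of what the source reports. "The series", "measured", "known", "first", "only" and "open" are said of these compounds alone.

Values in an ADME assay on NCI-H460 cells (Homo sapiens) for cytotoxicity; on this read-out higher numbers stand for weaker inhibition and lower numbers for stronger inhibition
- Compound 1 `Oc1cc(O)cc(CCCCCCCCCCCCCCc2cc(O)cc(O)c2)c1` gives 28800 nM 
- Compound 2 `Oc1cc2cc(c1)Oc1c(O)cc(cc1O)[C@H](O)CCCCCC/C=C/CCCCC2` gives 27900 nM 
- Compound 3 `COc1cc(O)cc(CCCCCCCCCCCCCCc2cc(O)cc(O)c2)c1` is not yet measured

Compound 1 stands level with compound 2, the two values lying within the scatter of each other. Compound 3 differs from compound 1 by methyl in place of hydrogen on an oxygen on an aromatic ring in one place, methyl in place of hydrogen on an oxygen on an aromatic ring. Going by the values given here, no measured pair shows this change, so no step beyond the scatter is expected in this assay and no direction is predicted. The expected change is a 1.2-fold lower number from compound 1 to compound 3 (0.06 log units; within the scatter) and stays within the scatter. Compound 3 is estimated at 25000 nM with an expected range of 10000 nM to 60000 nM in this read-out.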

Compound 3, half-maximal inhibitory concentration: 28700 nM
Beside the measured number, compound 3's estimate is 1.1-fold (0.06 log units) below it; low and high end bracket the measured number.
By their numbers in this assay, from the lowest: compounds 2, 3 and 1 (each within the scatter of the next).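

In this assay, hydroxy to methoxy on one 3,5-dihydroxyphenyl group gives a 1.0-fold lower number from compound 1 to compound 3 (0.00 log units; within the scatter). Going by these compounds alone, this is the first pair differing in one place, and it shows that methyl in place of hydrogen on this oxygen leaves the value within the scatter, so this one free hydroxy is not needed to hold the value at this level. Still open, on these data alone, is whether a larger ether such as benzyloxy, an amine in place of hydroxy, or methoxy on the remaining oxygens would also leave the value level. No evidence bears on why the value holds.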